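Sulfur returns to the side chain of compound 3

A few compounds are considered here, and "the series" means these few. Any claim that something is new, unique, unknown or untested is made for them only; others in the source may bear on it.

Measured in an ADME assay on HEK-293T cells (Homo sapiens) for cytotoxicity, read by CCK-8 assay, with a stated time of 48 h; a higher number here means a weaker inhibitor, a lower number a stronger inhibitor
Compound 1 `O=C(Nc1cccc([N+](=O)[O-])c1)N1CCN(S(=O)(=O)c2sccc2-c2ccccc2Oc2ccc(O)c(O)c2)CC1` gives > 20000 nM as a limit
Compound 2 `O=S(=O)(NCCNC(=S)Nc1cccc(Cl)c1)c1ccc(-c2ccccc2OCc2ccccc2)s1` gives 10200 nM as a number
Compound 3 `COc1cccc(NC(=O)NCCNS(=O)(=O)c2ccc(-c3ccccc3OCc3ccccc3)s2)c1` gives > 20000 nM as a limit

The entry for compound 3 is > 20000 nM and this is a limit, not a number. It stands at the limit of > 20000 nM in this assay, at which 2 of the 3 values shown sit, and so has no exact place on the scale. Compound 4 `O=[N+]([O-])c1cccc(NC(=S)NCCNS(=O)(=O)c2ccc(-c3ccccc3OCc3ccccc3)s2)c1` comes from compound 3 by one change: a group of 12 heavy atoms (7 carbon, 2 nitrogen, 2 oxygen, 1 sulfur; one six-membered aromatic ring of carbon only) in place of a group of 11 heavy atoms (8 carbon, 1 nitrogen, 2 oxygen; one six-membered aromatic ring of carbon only), on an amine nitrogen and the group that leaves is (3-methoxyphenyl)carbamoyl. The group that enters has no common name, but it contains sulfur, as does the group on the amine nitrogen of compound 2.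

Among the measured compounds shown here, one measured step bears on this change: an at least 1.9-fold higher number from compound 2 to compound 3 (0.29 log units; that floor lies within the scatter) and it also takes place on an amine nitrogen. Going by these compounds, its size is only a floor, so the true gap remains unknown. For the measured compounds named here, compound 2 gives 10200 nM and this is the only number available, so a value for compound 4 somewhat nearer to it is expected, meaning a somewhat stronger inhibitor. A second limit remains quite possible. The expected change is an at least 1.4-fold lower number from compound 3 to compound 4 (0.15 log units; that floor lies within the scatter) and it may not prove larger than the scatter. Compound 4 is estimated at 14000 nM and is expected to fall from 6000 nM to 28000 nM in this assay when measured.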

Compound 4, half-maximal inhibitory concentration: 18300 nM
Compound 4: the middle estimate sits 1.3-fold (0.12 log units) below what was measured; low and high end bracket the measured number.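

Compound 4 gives a second exact number for a compound with a sulfur-bearing side chain on the amine nitrogen, and nitro in place of chloro on an aromatic carbon gives a 1.8-fold higher number from compound 2 to compound 4 (0.25 log units; within the scatter) in this assay, so compound 2 and compound 4 cannot be told apart in this assay. The other comparison, an at least 1.0-fold lower number from compound 3 to compound 4 (0.03 log units; that floor lies within the scatter), is only a floor and lies within the scatter, so it shows neither a real gain nor a real loss on swapping the (3-methoxyphenyl)carbamoyl group for the sulfur-containing one. Going by these compounds, the true size of that step remains unknown because the entry for compound 3 is a limit, not a number: the limit of > 20000 nM in this assay, at which 2 of the 4 values shown sit.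

Compound 3 and compound 4 differ both in the sulfur of the side chain and in the group on the aromatic ring, so the compounds shown cannot separate what each of these contributes. On these data alone, it also remains open how this assay would respond to an amine or a carboxylic acid in place of the nitro group, or to a longer chain on the sulfonamide nitrogen.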